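The compounds below may be only part of what the source reports. "The series", "measured", "known", "first", "only" and "open" are said of these compounds alone.

For the measured compounds named here, in a functional assay on HeLa cells (Homo sapiens) for antiproliferative activity, read by MTT assay, with a stated time of 48 h, in the presence of a further agent that is not named here (on this read-out lower numbers stand for stronger inhibition of growth and higher numbers for weaker inhibition of growth), the series so far holds three measured compounds. Compound 1 `O=C(NOCc1ccccc1Cl)c1cn(-c2ccccc2)nc1-c1ccccc1` gives 17800 nM. Going by the values given here, compound 2 `COc1ccc(-c2nn(-c3ccccc3)cc2C(=O)NOCc2ccccc2Cl)cc1` gives 3480 nM; the step of a 5.1-fold lower number from compound 1 to compound 2 (0.71 log units; beyond the scatter) is the only single-place change measured so far. Compound 3 `O=C(NOCc1ccccc1)c1cn(-c2ccccc2)nc1-c1ccc(Cl)cc1` gives 8350 nM, the second highest of the three numbers: its value sits between those of compound 1 and compound 2, both gaps beyond the scatter, but neither pair differs in one place, so only the two values themselves can be set side by side. Compound 4 `O=C(NOCc1ccccc1Cl)c1cn(-c2ccccc2)nc1-c1ccc(Cl)cc1` has not yet been measured in this assay. It differs from compound 3 by chloro in place of hydrogen on an aromatic carbon, ortho to a large group on the benzyl part. Among the compounds with values here, the one measured step concerns a methoxy group entering a different part of the molecule and does not bear on a chloro entering here; no measured step tests this change. With nothing to lean on, compound 4 is expected to show a 1.3-fold lower number from compound 3 to compound 4 (0.11 log units; within the scatter), a step not beyond the scatter, so compound 4 is estimated at 6500 nM with a range from 2500 nM to 17000 nM.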

Compound 4, concentration for 50% growth inhibition: 8850 nM
For compound 4 the middle estimate is 1.4-fold (0.13 log units) below the measured one; measured number inside the range.
By their numbers in this assay, from the lowest: compound 2; then compounds 3, 4 and 1 (each within the scatter of the next, the first and the last beyond it).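

In this assay, the change from benzyl to 2-chlorobenzyl gives a 1.1-fold higher number from compound 3 to compound 4 (0.03 log units; within the scatter), so chloro at this position leaves the number within the scatter, at least with a chloro already on the other phenyl group. That other phenyl group now gets its first chloro reading: chloro in place of hydrogen gives a 2.0-fold lower number from compound 1 to compound 4 (0.30 log units; within the scatter), while chloro in place of methoxy gives a 2.5-fold higher number from compound 2 to compound 4 (0.41 log units; beyond the scatter), so at that place methoxy separates from chloro but chloro does not separate from hydrogen. No supporting measurement bears on why these steps have these sizes.

From the compounds shown here alone, it remains open whether the flat response to chloro on the benzyl part would hold with methoxy or hydrogen on the other phenyl group. Also open, going by these compounds, is how an amine, a carboxylic acid or a longer chain would read at the position ortho to a large group.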